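Swapping a halogenated phenyl ring on the hydrazone nitrogen

A few compounds are considered here, and "the series" means these few. Any claim that something is new, unique, unknown or untested is made for them only; others in the source may bear on it.

For the measured compounds named here, the two compounds measured so far share a core that carries a carboxylic acid and a hydrazone-linked aryl ring. Compound 1, `CCOC(=O)c1cnc2n(c1=O)C(C)CC/C2=N\Nc1ccc(C(=O)O)cc1`, gives 100 umol/kg in a functional assay on the whole organism for inhibition, with Rattus norvegicus as the target; on this read-out higher numbers stand for an effect only at larger amounts of compound and lower numbers for an effect already at smaller amounts. Compound 2, `CC1CC/C(=N\Nc2ccc(F)cc2)c2ncc(C(=O)O)c(=O)n21`, gives 12.2 umol/kg in this assay, the lower of the two numbers, and the gap to compound 1 lies beyond the scatter of the method.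

Compound 3, `CC1CC/C(=N\Nc2cccc(Br)c2)c2ncc(C(=O)O)c(=O)n21`, has not been measured. It differs from compound 2 in one place: 3-bromophenyl in place of 4-fluorophenyl on an amine nitrogen. Going by the values given here, no measured pair shows this change, so nothing here tells how the number should move. Compound 3 is therefore expected to stay near compound 2 in this assay, with an estimated step of a 1.2-fold higher number from compound 2 to compound 3 (0.09 log units; within the scatter), no larger than the scatter. The estimate for compound 3 is 15 umol/kg, in a range from 5 umol/kg to 45 umol/kg.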

Compound 3, dose for 50% inhibition: 0.4 umol/kg
The estimate for compound 3 lay 38-fold (1.57 log units) above the measured number; the whole stated range lies above it.
By their numbers in this assay, from the lowest: compound 3; then compound 2; then compound 1.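

In this assay, the place on the amine nitrogen turns out to be highly sensitive to the aryl group it carries: 3-bromophenyl in place of 4-fluorophenyl gives a 31-fold lower number from compound 2 to compound 3 (1.48 log units; beyond the scatter). The earlier compounds shown here could not show this, since compound 1 and compound 2 differ in more than one place and so isolated no single change. Here the two groups match in their counted features, each with the same number of heavy atoms, one aromatic ring of carbon only and no net charge, yet the number still moves well beyond the scatter, and nothing available accounts for the size of this step.

For the compounds shown here, the single step changes both the halogen and where it sits on the ring, so the two cannot be told apart. A 4-bromophenyl or a 3-fluorophenyl group on the same nitrogen would separate them.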